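Branched hydroxyl group on the triazole: an estimate

The source may report more compounds than this note shows. Statements on the series, on what has been measured and on what is new or still open speak of the compounds shown alone.

Measured so far:
compound 1, `CC(C)(C)c1cn(CCNc2nonc2/C(=N/O)Nc2ccc(F)c(Br)c2)nn1`, gives 132 nM;
compound 2, `OCCCc1cn(CCNc2nonc2/C(=N/O)Nc2ccc(F)c(Br)c2)nn1`, gives 98 nM;
compound 3, `OCCCCc1cn(CCNc2nonc2/C(=N/O)Nc2ccc(F)c(Br)c2)nn1`, gives 80 nM.

These three numbers come from an assay on isolated protein for inhibition of Indoleamine 2,3-dioxygenase 1 (Homo sapiens); on this read-out higher numbers stand for weaker inhibition and lower numbers for stronger inhibition. Compound 2 stands second highest of the three, yet all three lie within the scatter of one another: the step of a 1.3-fold lower number from compound 1 to compound 2 (0.13 log units; within the scatter) and the step of a 1.2-fold lower number from compound 2 to compound 3 (0.09 log units; within the scatter) are both small, as is the step of a 1.7-fold lower number from compound 1 to compound 3 (0.22 log units; within the scatter). So swapping the group on the triazole carbon between a branched hydrocarbon and a straight chain carrying a hydroxyl has so far left the read-out essentially unchanged.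

Compound 4, `CC(C)(O)c1cn(CCNc2nonc2/C(=N/O)Nc2ccc(F)c(Br)c2)nn1`, has not been measured. The change from compound 2 is 1-hydroxy-1-methylethyl in place of 3-hydroxypropyl on an aromatic carbon. The new group resembles the tert-butyl of compound 1 with one methyl replaced by a hydroxyl, so compound 1 and compound 2 both bear on it, and neither step was beyond the scatter. In this assay the step from compound 2 to compound 4 is therefore expected to be small, a 1.1-fold higher number from compound 2 to compound 4 (0.05 log units; within the scatter), with no clear direction. Compound 4 is estimated at 110 nM, within 55 nM to 220 nM.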

Compound 4, half-maximal inhibitory concentration: 115 nM
Compound 4: middle estimate off by 1.0-fold (0.02 log units), on the low side, and the stated range covers the measured number.
By their numbers in this assay, from the lowest: compounds 3, 2, 4 and 1 (each within the scatter of the next).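

In this assay, rearranging the same atoms from 3-hydroxypropyl into 1-hydroxy-1-methylethyl gives a 1.2-fold higher number from compound 2 to compound 4 (0.07 log units; within the scatter), and replacing 4-hydroxybutyl with this group gives a 1.4-fold higher number from compound 3 to compound 4 (0.16 log units; within the scatter). Hydroxy in place of methyl on the branched group gives a 1.1-fold lower number from compound 1 to compound 4 (0.06 log units; within the scatter), so on this aromatic carbon the read-out does not separate a hydroxyl at the end of a straight chain from one on the chain carbon bound to the aromatic carbon, nor a hydroxyl from a methyl on that branched carbon. The data shown offer nothing that explains why these changes stay so small.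

Going by these compounds, whether an amine or a carboxylic acid in place of the hydroxyl would move the number beyond the scatter remains open. So does the effect of a much longer chain at this position.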